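The source may report more compounds than this note shows. Statements on the series, on what has been measured and on what is new or still open speak of the compounds shown alone.

For the measured compounds named here, in a functional assay on MCF7 cells (Homo sapiens) for inhibition, read by MTT assay, with a stated time of 24 h (on this read-out higher numbers stand for weaker inhibition of growth and lower numbers for stronger inhibition of growth), three compounds have numbers so far. Compound 1 (`Cn1cc(-c2nc3ccccc3n2C(=O)c2cccc(Br)c2)c2ccccc21`) gives 63400 nM, compound 2 (`COc1ccc(C(=O)n2c(-c3cn(C)c4ccc(Br)cc34)nc3ccccc32)cc1`) gives 19200 nM, and compound 3 (`COc1ccc(C(=O)n2c(-c3cn(C)c4ccc(Br)cc34)nc3ccccc32)cc1OC`) gives 11300 nM. Compound 3 therefore sits with compound 2 at the low end of these numbers, the two lying within the scatter of each other, while compound 1 stands clearly above compound 3, beyond the scatter.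

The next compound to consider is compound 4 (`Cn1cc(-c2nc3ccccc3n2C(=O)c2cccc(Br)c2)c2cc(Br)ccc21`). The change from compound 3 is 3-bromophenyl in place of 3,4-dimethoxyphenyl on a carbonyl carbon.

Going by the values given here, only one measured step touches this change. It is a 1.7-fold lower number from compound 2 to compound 3 (0.23 log units; within the scatter), for methoxy in place of hydrogen on an aromatic carbon, and it stays within the scatter. Among the compounds with values here, it suggests that losing the methoxy groups need not matter much, though no measured step covers the full swap. Compound 1 also carries 3-bromophenyl on a carbonyl carbon, and its value of 63400 nM hints at a move upward. A small upward step is therefore expected in this assay, estimated as a 1.8-fold higher number from compound 3 to compound 4 (0.25 log units; within the scatter). Compound 4 is expected to give about 20000 nM, with an estimated range from 8000 nM to 50000 nM.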

Compound 4, concentration for 50% growth inhibition: 68200 nM
Beside the measured number, compound 4's estimate is 3.4-fold (0.53 log units) below it, outside the stated range (above it).
By their numbers in this assay, from the lowest: compounds 3 and 2 (each within the scatter of the next); then compounds 1 and 4 (each within the scatter of the next).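

In this assay, the group on the carbonyl carbon turns out to matter: 3-bromophenyl in place of 3,4-dimethoxyphenyl gives a 6.0-fold higher number from compound 3 to compound 4 (0.78 log units; beyond the scatter), and 3-bromophenyl in place of 4-methoxyphenyl gives a 3.6-fold higher number from compound 2 to compound 4 (0.55 log units; beyond the scatter), so both swaps weaken growth inhibition beyond the scatter, whereas the earlier methoxy step stayed within it. The other new comparison, bromo in place of hydrogen on an aromatic carbon of the core, shows a 1.1-fold higher number from compound 1 to compound 4 (0.03 log units; within the scatter), so with 3-bromophenyl on the carbonyl carbon this bromo makes no difference that can be read. Nothing available here offers a reason for the weaker numbers with 3-bromophenyl.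

The compounds shown cannot tell whether the methoxy groups help or the bromo on the phenyl ring hurts; an unsubstituted phenyl on the carbonyl carbon would separate the two, and an aminophenyl or a carboxyphenyl would test quite different groups there. Going by these compounds, it also stays open whether the core bromo would remain without a readable effect when 4-methoxyphenyl or 3,4-dimethoxyphenyl sits on the carbonyl carbon.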